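Adding a Methyl Next to the Amide Carbonyl

This account rests on a few compounds, and the source may have more. Where it says the series, first, only, none or still open, it means among the compounds named here.

Compound 1 `Cc1cc(OCCCS(C)(=O)=O)cc(C)c1-c1cccc(COc2ccc(OCC(=O)O)c(F)c2)c1`: 2.31
Compound 2 `O=C(O)COc1ccc(NC(=O)COc2ccccc2)cc1F`: -1.25

Of the compounds shown here, two have been measured in a physicochemical assay for lipophilicity, using the shake flask method, at pH 7.4; on this read-out lower numbers stand for lower lipophilicity and higher numbers for higher lipophilicity. Compound 1 gives 2.31 in this assay, while compound 2 gives -1.25, which places compound 2 at the lower of the two numbers and well apart from compound 1. The two structures share only part of their framework, so nothing can be read from the gap between them about a single change.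

Compound 3 `CC(Oc1ccccc1)C(=O)Nc1ccc(OCC(=O)O)c(F)c1` differs from compound 2 in one place: methyl in place of hydrogen on a saturated chain carbon bound to a carbonyl carbon and an oxygen on an aromatic ring. Going by the values given here, no measured pair in this set carries a matching change, so the expectation rests on the size of the group alone. A small rise in this assay is expected from compound 2 to compound 3, estimated at a number 0.40 log units higher from compound 2 to compound 3 (beyond the scatter), possibly within the scatter. Compound 3 is therefore expected to give about -0.85 in this assay, with a range from -1.35 to -0.35.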

Compound 3, distribution coefficient: -0.18
For compound 3 the middle estimate is 0.67 log units below the measured one; measured number outside the range, above it.
By their numbers in this assay, from the lowest: compound 2; then compound 3; then compound 1.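

Going by these compounds alone, the step of a number 1.07 log units higher from compound 2 to compound 3 (beyond the scatter) in this assay is large and is the first change in this set that can be read at a single place. It shows that methyl in place of hydrogen, on a saturated chain carbon bound to a carbonyl carbon and an oxygen on an aromatic ring, moves the read-out well beyond the scatter, even though only 1 heavy atom enters. Nothing measured here accounts for the size of this step.

The compounds shown leave open whether the rise continues with an ethyl or a longer chain at this carbon, or whether a second methyl or a fluorine there would give a comparable step. They also leave open whether methyl would produce a step of similar size at any other place on the chain.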